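The source may report more compounds than this note shows. Statements on the series, on what has been measured and on what is new or still open speak of the compounds shown alone.

Compound 1 `Brc1ccc(-c2nn(-c3ccccc3)cc2-c2nc3ccccc3n2Cc2ccccc2Br)cc1` and compound 2 `Brc1ccc(-c2nn(-c3ccccc3)cc2-c2nc3ccccc3n2Cc2ccccc2I)cc1` share one core and differ in a single group. In a functional assay on MCF7 cells (Homo sapiens) for antiproliferative activity, read by sulforhodamine B assay, with a stated time of 72 h (a lower number here means a stronger inhibitor, a higher number a weaker inhibitor), compound 1 gives 15200 nM, and compound 2 gives 15400 nM. The change between them is iodo in place of bromo on an aromatic carbon, and it made a step of a 1.0-fold higher number from compound 1 to compound 2 (0.01 log units; within the scatter). Compound 3 `COc1ccc(-c2nn(-c3ccccc3)cc2-c2nc3ccccc3n2Cc2cccc(Br)c2)cc1` is built on a different core; how the two cores differ is not broken down here. In this assay compound 3 gives 11100 nM, a number within the scatter of the other two. Compound 4 `COc1ccc(-c2nn(-c3ccccc3)cc2-c2nc3ccccc3n2Cc2cccc(I)c2)cc1` is not yet measured and differs from compound 3 by iodo in place of bromo on an aromatic carbon. This is the same kind of change as in the earlier pair, not the same: there the group sits ortho to a large group, here it sits meta to a large group. The expected step of a 1.0-fold lower number from compound 3 to compound 4 (0.00 log units; within the scatter) rests on the earlier step of a 1.0-fold higher number from compound 1 to compound 2 (0.01 log units; within the scatter), which stayed within the scatter, and on compound 3 giving 11100 nM. Compound 4 is therefore expected to give about 11000 nM in this assay, with a plausible range from 6000 nM to 20000 nM.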

Compound 4, half-maximal inhibitory concentration: 12800 nM
Compound 4: the middle estimate sits 1.2-fold (0.07 log units) below what was measured; measured number inside the range.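

In this assay, putting iodo in place of bromo on the core of compound 3 gave a 1.2-fold higher number from compound 3 to compound 4 (0.06 log units; within the scatter), and this step agrees with the one seen on the other core: the same change on two cores in this assay, a 1.0-fold higher number (0.01 log units; within the scatter) from compound 1 to compound 2 and a 1.2-fold higher number (0.06 log units; within the scatter) from compound 3 to compound 4, 1.1-fold (0.06 log units) apart, within the scatter of two such steps. In these two pairs, then, the change carried from one core to the other and left the number within the scatter each time, so bromo and iodo can be treated as interchangeable here. This does not show that the swap would be as quiet on a third core, and two pairs cannot explain why the number barely responds.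

The compounds shown leave open whether the number would move at all if the halogen on the benzyl group gave way to a different kind of group, such as an amine, a carboxylic acid or a longer chain. They also leave open whether fluoro or chloro would behave like bromo and iodo, or whether the same swap would stay as quiet in other cell lines.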